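The source may report more compounds than this note shows. Statements on the series, on what has been measured and on what is new or still open speak of the compounds shown alone.

In a functional assay on the whole organism for inhibition, with Rattus norvegicus as the target, read by paw edema, with stated times of 1 h and 3 h (a higher number here means that more compound is needed for the effect, a lower number that less compound is needed), compound 2 `C/C(=N\OCC(N)=O)c1ccc(Cl)cc1` gives 24 mg/kg. Compound 1 `COC(=O)CO/N=C(\C)c1ccc(Cl)cc1` gives 24 mg/kg, level with compound 2, and together they hold the lowest of the three numbers measured. Compound 3 `C/C(=N\OCC(N)=O)c1ccc(Br)cc1` gives 62 mg/kg. Compound 4 `C/C(=N\NCC(=O)O)c1ccc(Cl)cc1` has the same atoms as compound 2, joined differently, with (carboxymethyl)amino in place of carbamoylmethoxy on a double-bonded nitrogen.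

The measured steps bear on this only in part. Amino in place of methoxy on a carbonyl carbon gave no change at the digits printed from compound 1 to compound 2 (within the scatter). Bromo in place of chloro on an aromatic carbon gave a 2.6-fold higher number from compound 2 to compound 3 (0.41 log units; beyond the scatter), but that change lies at a different place. Within the data shown here, no measured compound carries the (carboxymethyl)amino group, so the data offer no direct precedent. With compound 2 already at the low end of the series at 24 mg/kg, a modest move to a higher number seems more likely than a further drop. The expected step is a 1.7-fold higher number from compound 2 to compound 4 (0.22 log units; within the scatter), and this estimate is loose. For compound 4 the estimated value is 40 mg/kg, with an expected range from 15 mg/kg to 110 mg/kg.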

Compound 4, dose for half-maximal effect: 22 mg/kg
The estimate for compound 4 lay 1.8-fold (0.26 log units) above the measured number; low and high end bracket the measured number.
By their numbers in this assay, from the lowest: compounds 4, 1 and 2 (each within the scatter of the next); then compound 3.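

In this assay, (carboxymethyl)amino in place of carbamoylmethoxy on a double-bonded nitrogen gives a 1.1-fold lower number from compound 2 to compound 4 (0.04 log units; within the scatter). The earlier steps shown here touched only a carbonyl carbon and an aromatic carbon, whereas this one shows that the group on the double-bonded nitrogen can be rejoined from the same atoms, with more hydrogen-bond donors in the entering group, and the number stays within the scatter. No measurement at hand explains this outcome.

Since the link to the double-bonded nitrogen and the end of the chain differ together, the compounds shown do not separate their contributions, which a carboxylic acid joined through oxygen or a primary amide joined through nitrogen would address. Also open, on these data alone, is how a longer chain ending in a carboxylic acid would read in this assay.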